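Hydrazone substituent swap on the shared core

The compounds below may be only part of what the source reports. "The series", "measured", "known", "first", "only" and "open" are said of these compounds alone.

Measured so far:
compound 1 `CCOC(=O)C1=C(N/N=C(\c2ccc([N+](=O)[O-])cc2)N2CCN(c3ccc(F)cc3)CC2)Nc2[nH]nc(C)c2C1c1ccc(N(C)C)cc1` — 90200 nM
compound 2 `CCOC(=O)C1=C(NN=C(C#N)C#N)Nc2[nH]nc(C)c2C1c1ccc(N(C)C)cc1` — 13700 nM

Both numbers come from a functional assay on HepG2 cells (Homo sapiens) for inhibition, read by MTT assay, with a stated time of 48 h; on this read-out lower numbers stand for stronger inhibition and higher numbers for weaker inhibition. Compound 2 holds the lowest number of the two, and compound 1 stands well above it, beyond the scatter. Going by the values given here, no single-point step between measured compounds exists, so the gap can only be read as what the two values show.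

Compound 3 `CCOC(=O)C1=C(N/N=C(/C(=O)Br)c2ccc(Cl)cc2)Nc2[nH]nc(C)c2C1c1ccc(N(C)C)cc1` is not yet measured. It differs from compound 2 as follows: a group of 12 heavy atoms (8 carbon, 1 nitrogen, 1 oxygen, 1 chlorine, 1 bromine; one six-membered aromatic ring of carbon only) in place of a group of 6 heavy atoms (3 carbon, 3 nitrogen; no ring), on an amine nitrogen. Nothing in the measured pair isolates this change. Among the compounds with values here, the only comparison available is that compound 1, which also carries a larger group on the same nitrogen, gives 90200 nM, a higher number than compound 2. On that basis a modest rise in the number is expected, a 2.2-fold higher number from compound 2 to compound 3 (0.34 log units; beyond the scatter), possibly not beyond the scatter. Compound 3 is estimated at 30000 nM, with a range from 8000 nM to 110000 nM.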

Compound 3, half-maximal inhibitory concentration: 50300 nM
Compound 3: the middle estimate sits 1.7-fold (0.22 log units) below what was measured; the range from low to high includes it.
By their numbers in this assay, from the lowest: compound 2; then compounds 3 and 1 (each within the scatter of the next).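

In this assay, the amine nitrogen now has its first change in one place: a 3.7-fold higher number from compound 2 to compound 3 (0.56 log units; beyond the scatter), with a group of 12 heavy atoms carrying one six-membered aromatic ring of carbon only in place of a group of 6 heavy atoms with no ring. The step is modest but beyond the scatter, so the number at this position does depend on the group attached, and compound 3 stands within the scatter of compound 1, which also carries a larger group on this nitrogen. No measurement on hand bears on the reason for this step.

One step cannot separate the contributions of the aromatic ring, the chlorine and the carbonyl bromide. As far as these compounds go, whether an amide or a carboxylic acid in place of the carbonyl bromide, or an unsubstituted phenyl ring, would bring the number back towards that of compound 2 remains open.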